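The source may hold more compounds than are shown below. What is called first, only, known or untested is meant among the compounds shown, and "the series" means these compounds.

Working notes on the series. In a functional assay on OVCAR-5 cells (Homo sapiens) for inhibition (on this read-out lower numbers stand for stronger inhibition of growth and higher numbers for weaker inhibition of growth), compound 1 `Nc1ccc(-c2nc3ccc(F)cc3s2)cc1I` gives 100 nM, the lower of the two exact numbers available. Compound 2 `Cc1cc(-c2nc3c(F)cccc3s2)ccc1N` gives 1700 nM, a higher number by a margin beyond the scatter. Compound 3 `Nc1ccc(-c2nc3cc(F)ccc3s2)cc1Cl` gives < 10 nM, which is a limit of the assay and not a number.

The next compound to consider is compound 4 `Cc1cc(-c2nc3ccc(F)cc3s2)ccc1N`. It arises from compound 1 through methyl in place of iodo on an aromatic carbon, ortho to an amino group and meta to a large group.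

Going by the values given here, no measured pair in the set shows this change on its own, so the expectation rests on thin evidence. In this assay, a small move towards a lower number is expected, one that may not clear the scatter. The expected step is a 1.7-fold lower number from compound 1 to compound 4 (0.22 log units; within the scatter). Compound 2 also bears a methyl group and gives 1700 nM, so the upper end of the range is kept generous. The lower end is set by the assay limit seen with compound 3 at < 10 nM. In this assay, the estimate for compound 4 is 60 nM, with an expected range of 10 nM to 400 nM.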

Compound 4, concentration for 50% growth inhibition: > 100000 nM
Compound 4 gave a limit, no number (the forecaster's own chance of this, stated with the estimate: 20%); middle value at least 1600-fold (3.22 log units) away from the limit.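

Methyl in place of iodo on an aromatic carbon, ortho to an amino group and meta to a large group, gives an at least 1000-fold higher number from compound 1 to compound 4 (3.00 log units; beyond the scatter) in this assay, and this is the only change in a single place that can be read in the series so far. The change therefore shows that the group at this position can decide whether growth inhibition is seen at all, even though iodo and methyl each count one heavy atom and neither adds a ring, a hydrogen-bond donor or a hydrogen-bond acceptor. The reading for compound 4 is a limit of the assay and not a number, so the full size of the step stays unknown: the limit of > 100000 nM in this assay, at which 1 of the 4 values shown sits.

The compounds shown leave open how groups such as bromo, methoxy or trifluoromethyl would read at this position, and so whether methyl stands alone or marks a wider trend. With a single pair, the step cannot be taken as a rule for the series, and these values give no cause for it.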